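Trifluoromethoxy at the methyl site of the shared core

The compounds below may be only part of what the source reports. "The series", "measured", "known", "first", "only" and "open" are said of these compounds alone.

Among the compounds with values here, compound 2 `O=C(c1ncccc1-c1ncccn1)N1CC2(CC2)C[C@H]1CNc1ccc(C(F)(F)F)cn1` holds the lowest of the two numbers so far: in a functional assay on HEK293 cells for antagonist activity at Orexin receptor type 2 (Homo sapiens), read by FLIPR and calcium flux (a higher number here means a more potent compound, by a factor of ten per unit of this negative logarithm, a lower number a less potent compound), compound 2 gives 5. Its nearest neighbour is compound 1 `Cc1ccc(-c2ncccn2)c(C(=O)N2CC3(CC3)C[C@H]2CNc2ccc(C(F)(F)F)cn2)n1`, which in this assay gives 7.5; the only difference is hydrogen in place of methyl on an aromatic carbon, and that step, a number 2.50 log units lower from compound 1 to compound 2 (beyond the scatter), is far beyond the scatter.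

Compound 3 `O=C(c1nc(OC(F)(F)F)ccc1-c1ncccn1)N1CC2(CC2)C[C@H]1CNc1ccc(C(F)(F)F)cn1` is not yet measured. It differs from compound 2 by trifluoromethoxy in place of hydrogen on an aromatic carbon, so the group enters at the aromatic carbon next to the ring nitrogen and para to a pyrimidin-2-yl group, the same place where compound 1 carries its methyl. Within the data shown here, the one step that bears on this position is the loss from compound 1 to compound 2, and it shows that occupying this carbon matters greatly. A substituent of comparable or larger size is therefore expected to recover much of that loss, though the two groups differ and no direct data for trifluoromethoxy exist here. The expected step is a number 1.80 log units higher from compound 2 to compound 3 (beyond the scatter) in this assay. Compound 3 is estimated at 6.8, within the range 5.8 to 7.8.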

Compound 3, negative logarithm of the antagonist equilibrium constant: 6.9
The estimate for compound 3 lay 0.10 log units below the measured number; low and high end bracket the measured number.
By their numbers in this assay, from the lowest: compound 2; then compound 3; then compound 1.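

In this assay trifluoromethoxy on this aromatic carbon gives a number 1.90 log units higher from compound 2 to compound 3 (beyond the scatter) and so recovers most of the drop seen with hydrogen, which shows that the recovery is not unique to methyl: a second, quite different group also serves at this carbon. The two groups are still not interchangeable, since trifluoromethoxy in place of methyl gives a number 0.60 log units lower from compound 1 to compound 3 (beyond the scatter) and leaves methyl the better of the two substituents shown here, by a modest step. Nothing measured here accounts for either step.

With only hydrogen, methyl and trifluoromethoxy at this carbon, the compounds shown leave open whether the recovery follows the size of the group or its nature, and a methoxy, an ethyl, a chlorine or an amine here would help to separate those readings. They also leave open whether the same order of the three holds once the pyrimidin-2-yl group or the trifluoromethyl group elsewhere on the shared core is replaced.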